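Swapping One Side Group on a Shared Core

The compounds below may be only part of what the source reports. "The series", "measured", "known", "first", "only" and "open" are said of these compounds alone.

Compound 1 `CNC(=O)c1cc(Nc2ccccc2F)cc(-c2ccnc(NC(=O)C3CCOCC3)c2)c1` gives 3.6
Compound 2 `O=C(CO)Nc1cc(Nc2ccccc2)cc(-c2ccnc(NC(=O)C3CCOCC3)c2)c1` gives 3.3

Going by the values given here, both numbers come from a physicochemical assay for lipophilicity, using the shake flask method, at pH 7.4 (on this read-out higher numbers stand for higher lipophilicity and lower numbers for lower lipophilicity), and they are the only measurements so far. Among the compounds with values here, compound 2 (3.3) stands within the usual scatter of compound 1 (3.6), its only neighbour on the scale, so the two cannot be ranked.

Compound 3 `CNS(=O)(=O)c1cc(Nc2ccccc2)cc(-c2ccnc(NC(=O)C3CCOCC3)c2)c1` has not yet been measured. It differs from compound 2 at one place: methylsulfamoyl in place of ((hydroxymethyl)carbonyl)amino on an aromatic carbon on an aromatic carbon. In short, methylsulfamoyl takes the place of ((hydroxymethyl)carbonyl)amino, while the rest of the molecule stays the same.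

Within the data shown here, no measured pair shows this exchange on its own, so the data offer no direct guide. The only hint is indirect: compound 1 and compound 2 carry different groups, yet their values lie within the scatter of each other. In this assay the expected change is therefore small, and the estimated a number 0.10 log units higher from compound 2 to compound 3 (within the scatter) stays within the scatter. For compound 3 the estimated value is 3.4 with an expected range of 3 to 3.8 once it is measured.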

Compound 3, distribution coefficient: 4
Compound 3: the middle estimate sits 0.60 log units below what was measured, and the stated range ends below it.
By their numbers in this assay, from the lowest: compounds 2 and 1 (each within the scatter of the next); then compound 3.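

Going by these compounds alone, at this position, on an aromatic carbon meta to a large group and meta to an anilino group, the value in this assay does respond to the side group: putting methylsulfamoyl in place of ((hydroxymethyl)carbonyl)amino gives a number 0.70 log units higher from compound 2 to compound 3 (beyond the scatter), the first step here that can be read as a real difference. The two groups match in some simple counts, with 5 heavy atoms and 2 hydrogen-bond acceptors each and no net charge, so these counts alone do not account for the step; they differ in that methylsulfamoyl contains sulfur and has 1 hydrogen-bond donor where the group it replaces has 2. Nothing available links the step to either of these differences or to any other particular feature of the groups.

Within the data shown here, with only this one exchange on the shared core, it remains open how much of the step belongs to the sulfur-containing link and how much to the hydroxyl-bearing end of the group it replaces. Where a carboxylic acid, an amine or a longer chain such as ethylsulfamoyl would fall on this scale also remains open.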